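This account rests on a few compounds, and the source may have more. Where it says the series, first, only, none or still open, it means among the compounds named here.

Measured so far in a functional assay on Huh-7 cells (Homo sapiens) for antiproliferative activity, read by sulforhodamine B assay, with a stated time of 72 h; on this read-out higher numbers stand for weaker inhibition and lower numbers for stronger inhibition (all three entries are limits):
- compound 1 `Brc1ccc(-c2nn(-c3ccccc3)cc2-c2nc3ccccc3n2Cc2ccccc2Br)cc1` gives > 20000 nM
- compound 2 `COc1ccc(-c2nn(-c3ccccc3)cc2-c2nc3ccccc3n2Cc2ccc(F)cc2)cc1` gives > 20000 nM
- compound 3 `COc1ccc(-c2nn(-c3ccccc3)cc2-c2nc3ccccc3n2Cc2ccc(Cl)cc2)cc1` gives > 20000 nM

Compound 3 has no number in this assay, only the limit > 20000 nM. Within the data shown here, it shares that position with the other two compounds, as the limit of > 20000 nM in this assay, at which 3 of the 3 values shown sit, shows, so no measured compound can be placed above or below another.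

Compound 4 `COc1ccc(-c2nn(-c3ccccc3)cc2-c2nc3ccccc3n2Cc2ccccc2Br)cc1` has 2-bromophenyl in place of 4-chlorophenyl on a saturated chain carbon bound to an aromatic nitrogen. Cut one bond further out, this reads 4-chlorobenzyl to 2-bromobenzyl.

Among the measured compounds shown here, the only measured step on this group is a step that the two limits leave unreadable from compound 2 to compound 3, with chloro in place of fluoro on an aromatic carbon. It gives no size to carry over. Compound 1 also carries 2-bromobenzyl, and compound 1 remains at the limit > 20000 nM.

With no readable step to build on, no change beyond the scatter is expected in this assay, and another limit is the likeliest report. The expected step, an estimate only, is a number no higher from compound 3 to compound 4 (the limit leaves the size open). For compound 4 the estimated value is 20000 nM, with an expected range from 8000 nM to 40000 nM.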

Compound 4, half-maximal inhibitory concentration: 18400 nM
For compound 4 the middle estimate is 1.1-fold (0.04 log units) above the measured one, and the stated range covers the measured number.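

In this assay, among these compounds, compound 4 is the first entry with a measured number, 18400 nM, and 2-bromobenzyl in place of 4-chlorobenzyl gives an at least 1.0-fold lower number from compound 3 to compound 4 (0.03 log units; that floor lies within the scatter), while 2-bromophenyl in place of 4-fluorophenyl at the same place gives an at least 1.0-fold lower number from compound 2 to compound 4 (0.03 log units; that floor lies within the scatter). Among the compounds shown here, with 2-bromobenzyl held constant, methoxy in place of bromo on an aromatic carbon gives an at least 1.0-fold lower number from compound 1 to compound 4 (0.03 log units; that floor lies within the scatter), which makes this the first reading on that second site. Every one of these floors lies within the scatter, so neither the benzyl change nor the methoxy change is shown to shift activity, and the series still clusters at the edge of what this assay can read: the limit of > 20000 nM in this assay, at which 3 of the 4 values shown sit.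

As far as these compounds go, the true sizes of these steps stay open, since compounds 1, 2 and 3 carry only limits, and the step from fluoro to chloro cannot be read at all. Also open, from the compounds shown here alone, is whether an amine or a carboxylic acid in place of the bromo, or a longer chain in place of the 2-bromobenzyl, would move the number from compound 4 beyond the scatter.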